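Bromo for methoxy on two related cores

A few compounds are considered here, and "the series" means these few. Any claim that something is new, unique, unknown or untested is made for them only; others in the source may bear on it.

Compound 1 `COc1ccc(-c2cc3ccc(OCCCn4cc(CNC(=O)CCCCC5CCSS5)nn4)cc3oc2=O)cc1` in a functional assay on PC-12 cells (Rattus norvegicus) for cytotoxicity, read by MTT assay, with stated times of 3 h and 2 h, tested at 1 uM (on this read-out higher numbers stand for a stronger effect at the one concentration tested and lower numbers for a weaker effect), gives 47.4%. Compound 2 `O=C(CCCCC1CCSS1)NCc1cn(CCCOc2ccc3cc(-c4ccc(Br)cc4)c(=O)oc3c2)nn1` carries one change, (bromo in place of methoxy on an aromatic carbon); in this assay compound 2 gives 42.8%, which is a number 4.6 percentage points lower from compound 1 to compound 2 (within the scatter). Compound 3 `COc1ccc(-c2cc3ccc(OCCCCn4cc(CNC(=O)CCCCC5CCSS5)nn4)cc3oc2=O)cc1` rests on another core; the difference between the two cores is not broken down here. In this assay compound 3 gives 36.8%. Compound 4 `O=C(CCCCC1CCSS1)NCc1cn(CCCCOc2ccc3cc(-c4ccc(Br)cc4)c(=O)oc3c2)nn1` is not yet measured. Among the measured compounds shown here, it differs from compound 3 by bromo in place of methoxy on an aromatic carbon, the same change, at the same place, as the one between compound 1 and compound 2. For the measured compounds named here, the expected step is a number 3.8 percentage points lower from compound 3 to compound 4 (within the scatter), resting on the single earlier instance, a number 4.6 percentage points lower from compound 1 to compound 2 (within the scatter). Compound 4 is therefore estimated in this assay at 33%. The expected range for compound 4 runs from 22% to 44%.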

Compound 4, a percentage reported as activity, at one concentration (the size of the read-out at that concentration, not a potency): 37.4%
For compound 4 the middle estimate is 4.4 percentage points below the measured one, and the stated range covers the measured number.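

Carrying the change from 4-methoxyphenyl to 4-bromophenyl onto the second core gives, in this assay, a number 0.6 percentage points higher from compound 3 to compound 4 (within the scatter) and so agrees with the earlier instance: the same change on two cores in this assay, a number 4.6 percentage points lower (within the scatter) from compound 1 to compound 2 and a number 0.6 percentage points higher (within the scatter) from compound 3 to compound 4, 5.2 percentage points apart, within the scatter of two such steps. Among the compounds shown here, on these two cores, then, the change produces no step that stands out from the scatter. This rests on two pairs at one concentration and does not show that the change is without effect on other cores or at other concentrations.

The compounds shown leave open how a nitrile or an amine would read in place of the bromo on either core. Also open, as far as these compounds go, is how a longer chain than that of compound 4 would read with either group.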